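Swapping the Nitrooxy Ring for a Hydroxyphenyl Ring

A few compounds are considered here, and "the series" means these few. Any claim that something is new, unique, unknown or untested is made for them only; others in the source may bear on it.

Compound 1 `CN(C)CCn1cnnc1-c1cc(Oc2ccc(NC(=O)N/N=C/c3ccccc3O[N+](=O)[O-])cc2F)ccn1` was tested in a functional assay on U-87MG ATCC cells (Homo sapiens) for cytotoxicity, read by MTT assay, with a stated time of 72 h (a lower number here means a stronger inhibitor, a higher number a weaker inhibitor), where compound 1 gives 7150 nM, the highest of the two numbers shown. Its nearest neighbour is compound 2 `CN(C)CCn1cnnc1-c1cc(Oc2ccc(NC(=O)N/N=C/c3ccc(F)cc3F)cc2F)ccn1`, which in this assay gives 1900 nM. These two share one core and differ only in the ring on a carbon with a double bond to nitrogen; that change gives a 3.8-fold lower number from compound 1 to compound 2 (0.58 log units; beyond the scatter).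

Compound 3 `CN(C)CCn1cnnc1-c1cc(Oc2ccc(NC(=O)N/N=C/c3ccc(O)cc3)cc2F)ccn1` has not been measured yet. It differs from compound 1 as follows: 4-hydroxyphenyl in place of 2-(nitrooxy)phenyl on a carbon with a double bond to nitrogen. For the measured compounds named here, only one measured step speaks to this position, the one from compound 1 to compound 2, and it shows that exchanging the 2-(nitrooxy)phenyl group for another ring can lower the number by a modest amount. Because a 3.8-fold lower number from compound 1 to compound 2 (0.58 log units; beyond the scatter) points that way, a similar but uncertain improvement is expected for compound 3, although a 4-hydroxyphenyl group is not a 2,4-difluorophenyl group and the outcome could equally stay within the scatter. The expected step is a 2.0-fold lower number from compound 1 to compound 3 (0.31 log units; beyond the scatter). Compound 3 is therefore estimated to give 3500 nM in this assay, with a range from 1200 nM to 10000 nM.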

Compound 3, half-maximal inhibitory concentration: 7750 nM
Estimate against measurement, compound 3: 2.2-fold (0.35 log units) below, and the stated range covers the measured number.
By their numbers in this assay, from the lowest: compound 2; then compounds 1 and 3 (each within the scatter of the next).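

In this assay, the 4-hydroxyphenyl group and the 2-(nitrooxy)phenyl group cannot be told apart on the carbon with a double bond to nitrogen, since exchanging one for the other gives a 1.1-fold higher number from compound 1 to compound 3 (0.03 log units; within the scatter). Replacing the 2-(nitrooxy)phenyl group with a different ring therefore does not lower the number by itself, and among these three compounds only the 2,4-difluorophenyl group of compound 2 stands apart, as the exchange from that group to 4-hydroxyphenyl gives a 4.1-fold higher number from compound 2 to compound 3 (0.61 log units; beyond the scatter). No measurement at hand explains why the 2,4-difluorophenyl group differs from the other two groups in this assay.

The compounds shown leave open whether both fluorine atoms are needed for the lower number of compound 2, a question that a 4-fluorophenyl group, a 2-fluorophenyl group or a plain phenyl ring at this position could help to answer. They also leave open whether a 4-methoxyphenyl or 4-aminophenyl group would match the 4-hydroxyphenyl group of compound 3 or come closer to the 2,4-difluorophenyl group of compound 2.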